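A few compounds are considered here, and "the series" means these few. Any claim that something is new, unique, unknown or untested is made for them only; others in the source may bear on it.

Three compounds have been measured in a functional assay on UO-31 cells (Homo sapiens) for cytotoxicity, read by sulforhodamine B assay, with a stated time of 48 h, tested at 1 uM; a lower number here means a stronger effect, a higher number a weaker effect of the compound at the concentration tested:

Compound 1, `COc1cc(C)cc(-c2c(-c3ccnc(-c4ccc(N(C)C)cc4)c3)cnn2CC#N)c1`: 12%
Compound 2, `COc1cc(C)cc(-c2nn(CC#N)cc2-c2ccnc(-c3ccc(N(C)C)cc3)c2)c1`: 18%
Compound 3, `COc1cc(C)cc(-c2nn(CC#N)cc2-c2ccc(-c3cccc(C(C)=O)c3)nc2)c1`: 21%

Among these three numbers compound 2 stands second highest. Its nearest neighbour is compound 3, whose number is slightly higher, and its furthest is compound 1, whose number is somewhat lower; both gaps lie within the scatter, so the three readings cannot be told apart with confidence.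

Compound 4, `Cc1cc(O)cc(-c2nn(CC#N)cc2-c2ccnc(-c3ccc(N(C)C)cc3)c2)c1`, differs from compound 2 in one place: hydrogen in place of methyl on an oxygen on an aromatic ring. Within the data shown here, no measured pair shows this change, so nothing in the data points to a step in either direction. The change is expected to leave the reading roughly where it is, a step of a number 4 percentage points higher from compound 2 to compound 4 (within the scatter) in this assay, not beyond the scatter. Compound 4 is therefore estimated at 22%, within a range from 10% to 40%.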

Compound 4, a percentage reported as activity, at one concentration (the size of the read-out at that concentration, not a potency): 19%
Compound 4: middle estimate off by 3 percentage points, on the high side; the range from low to high includes it.
By their numbers in this assay, from the lowest: compounds 1, 2, 4 and 3 (each within the scatter of the next).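

The change from methoxy to hydroxy gives a number 1 percentage points higher from compound 2 to compound 4 (within the scatter) in this assay. Among these compounds, this is the first measured pair at this position, and the reading does not tell the two groups apart, so the methyl on the oxygen can be replaced by hydrogen with no change beyond the scatter. Nothing in the available data offers an explanation for this result.

On these data alone, whether an ethoxy group, an amine or a fluorine in place of the methoxy would read the same remains open. So does whether the same change behaves alike on compound 1 or compound 3.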